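A few compounds are considered here, and "the series" means these few. Any claim that something is new, unique, unknown or untested is made for them only; others in the source may bear on it.

Measured compounds:
- compound 1 `CCOC(=O)c1cnn(-c2nc(-c3ccc(OC)cc3)c(C#N)c(=O)n2C)c1N`: 59 ug/mL
- compound 2 `CCOC(=O)c1cnn(-c2nc(-c3cccc(OC)c3OC)c(C#N)c(=O)n2C)c1N`: 54 ug/mL
- compound 3 `CCOC(=O)c1cnn(-c2nc(-c3ccc(N(C)C)cc3)c(C#N)c(=O)n2C)c1N`: 98 ug/mL

All three compounds share one core and differ only in the aromatic group that sits on it. In a functional assay, with a stated time of 20 min (a lower number here means a stronger inhibitor, a higher number a weaker inhibitor), compound 3 gives the highest of the three numbers, yet its distance to the other two is small: the step of a 1.7-fold higher number from compound 1 to compound 3 (0.22 log units; within the scatter) and the step of a 1.8-fold higher number from compound 2 to compound 3 (0.26 log units; within the scatter) both stay within the scatter, as does the step of a 1.1-fold lower number from compound 1 to compound 2 (0.04 log units; within the scatter). So far, swapping one aromatic group for another at this position has not moved the numbers beyond what repeated measurements show on their own.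

Compound 4 `CCOC(=O)c1cnn(-c2nc(-c3ccco3)c(C#N)c(=O)n2C)c1N` continues this series with a different kind of aromatic group: furan-2-yl in place of 4-(dimethylamino)phenyl on an aromatic carbon. Among the compounds with values here, none of the measured steps covers a five-membered ring at this position, so the available steps bear on the change only in a general way. What they do show is that three different aromatic groups here gave numbers within the scatter of each other. On that basis the step of a 1.4-fold lower number from compound 3 to compound 4 (0.15 log units; within the scatter) is expected to be small, with no direction beyond the scatter. For compound 4 the estimated value in this assay is 70 ug/mL, with a range from 30 ug/mL to 160 ug/mL.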

Compound 4, half-maximal inhibitory concentration: 91 ug/mL
Beside the measured number, compound 4's estimate is 1.3-fold (0.11 log units) below it, within the range that was stated.
By their numbers in this assay, from the lowest: compounds 2, 1, 4 and 3 (each within the scatter of the next).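

Furan-2-yl brings a five-membered ring with one hetero atom to this position, and in this assay it stands within the scatter of all three groups before it (a 1.1-fold lower number from compound 3 to compound 4 (0.03 log units; within the scatter); a 1.7-fold higher number from compound 2 to compound 4 (0.23 log units; within the scatter); a 1.5-fold higher number from compound 1 to compound 4 (0.19 log units; within the scatter)). The numbers therefore do not separate even when 4-(dimethylamino)phenyl, with 9 heavy atoms and a ring of carbon only, gives way to a group of 5 heavy atoms, so neither ring size nor the ring oxygen produces a step beyond the scatter in this small set. Nothing measured alongside these numbers accounts for how closely they lie together.

As far as these compounds go, all four compounds carry an aromatic ring at this position, so what a saturated amine such as piperidine, a carboxylic acid or a longer alkyl chain would do there remains open. Also open, from the compounds shown here alone, is whether the numbers respond to changes elsewhere on the shared core, such as replacing the nitrile or the ethyl ester, which all four compounds keep.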